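From an Open Amine to an Aminopyrrolidine

A few compounds are considered here, and "the series" means these few. Any claim that something is new, unique, unknown or untested is made for them only; others in the source may bear on it.

Three compounds share a core in which an amide-linked trifluoromethylphenyl chain sits on one side and a substituted amino group on the other. In a functional assay on HEK293 cells for activation of melanin-concentrating hormone receptor 1 (Rattus norvegicus), read by inositol phosphate accumulation (a lower number here means that less compound is needed, a higher number that more compound is needed for the effect), compound 1 `CN(c1ccc2cc(NC(=O)CCc3ccc(C(F)(F)F)cc3)ccc2n1)C1CCCCC1` gives 1200 nM. Compound 2 `O=C(CCc1ccc(C(F)(F)F)cc1)Nc1ccc2nc(N3CCCCC3)ccc2c1` gives 110 nM in this assay, and compound 3 `CC(C)N(C)c1ccc2cc(NC(=O)CCc3ccc(C(F)(F)F)cc3)ccc2n1` gives 140 nM. Compound 3 thus stands second highest of the three numbers: nearest to compound 2, as the step of a 1.3-fold higher number from compound 2 to compound 3 (0.10 log units; within the scatter) shows, and far from compound 1, as an 8.6-fold lower number from compound 1 to compound 3 (0.93 log units; beyond the scatter) shows.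

Compound 4 `NC1CCN(c2ccc3cc(NC(=O)CCc4ccc(C(F)(F)F)cc4)ccc3n2)C1` differs from compound 3 in one place: 3-aminopyrrolidin-1-yl in place of isopropyl(methyl)amino on an aromatic carbon Of the measured steps, a 1.3-fold higher number from compound 2 to compound 3 (0.10 log units; within the scatter) shows that exchanging the open isopropyl(methyl)amino for a ring on that carbon left the number within the scatter, while an 8.6-fold lower number from compound 1 to compound 3 (0.93 log units; beyond the scatter) and an 11-fold lower number from compound 1 to compound 2 (1.04 log units; beyond the scatter) show that a larger cyclohexyl group pushed the number well up. Among the compounds with values here, no measured step carries an amino group on the entering ring, so that part is untested. Compound 4 is therefore expected to show a step of a 1.4-fold higher number from compound 3 to compound 4 (0.15 log units; within the scatter), little beyond the scatter but with a wide margin. The estimate for compound 4 is 200 nM, with a range from 50 nM to 900 nM.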

Compound 4, half-maximal effective concentration: 200 nM
For compound 4 middle estimate and measured number coincide at the digits printed; the measured number falls inside the stated range.
By their numbers in this assay, from the lowest: compounds 2, 3 and 4 (each within the scatter of the next); then compound 1.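

On the aromatic carbon next to the ring nitrogen, the shared core accepts a group that brings 1 hydrogen-bond donor, which neither earlier group on that carbon among compounds 2 and 3 has: in this assay the result is a 1.4-fold higher number from compound 3 to compound 4 (0.15 log units; within the scatter) and a 1.8-fold higher number from compound 2 to compound 4 (0.26 log units; within the scatter) with no separation from either. The five-membered ring with its amino group therefore sits with the isopropyl(methyl)amino and piperidin-1-yl groups, while a 6.0-fold lower number from compound 1 to compound 4 (0.78 log units; beyond the scatter) sets it clearly apart from the cyclohexyl(methyl)amino group. Nothing given here explains why the amino-bearing ring reads this way.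

Still open, from the compounds shown here alone, is how a plain pyrrolidin-1-yl, without the amino group, would read on this carbon. So too is whether a morpholin-4-yl or a piperazin-1-yl would stay with compounds 2, 3 and 4 or move towards compound 1.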